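Sulfonyl to carbamoyl on the shared core

This account rests on a few compounds, and the source may have more. Where it says the series, first, only, none or still open, it means among the compounds named here.

Measured in a functional assay on MKN-45 cells (Homo sapiens) for cytotoxicity; on this read-out higher numbers stand for weaker inhibition and lower numbers for stronger inhibition
compound 1 `COc1ccc(S(=O)(=O)N2CCc3cccc(NS(=O)(=O)c4ccc(F)cc4)c32)cc1` gives 890 nM
compound 2 `COc1ccc(S(=O)(=O)N2CCc3cccc(NC(=O)c4ccc(F)cc4)c32)cc1` gives 45 nM
compound 3 `COc1ccc(S(=O)(=O)N2CCc3cccc(NS(=O)(=O)c4ccccc4)c32)cc1` gives 562 nM

In this assay compound 3 sits with compound 1 at the high end of the three numbers, and the two lie within the scatter of each other. Compound 2 lies well clear of both. Compound 4 `COc1ccc(S(=O)(=O)N2CCc3cccc(NC(=O)N(C)c4ccccc4)c32)cc1` carries methyl(phenyl)carbamoyl in place of phenylsulfonyl on a nitrogen on an aromatic ring and keeps the rest of compound 3 unchanged.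

Going by the values given here, two measured steps bear most directly on this change. They are a 20-fold lower number from compound 1 to compound 2 (1.30 log units; beyond the scatter) and a 12-fold higher number from compound 2 to compound 3 (1.10 log units; beyond the scatter) and both are large, with the carbonyl-linked compound 2 on the low side each time. The third step, a 1.6-fold lower number from compound 1 to compound 3 (0.20 log units; within the scatter), stays within the scatter, so the two sulfonyl compounds read as one level. Among the compounds with values here, compound 4 also places a carbonyl on that nitrogen, but no measured compound carries methyl(phenyl)carbamoyl, so only part of the gap to compound 2 is expected to carry over. The expected change is a 4.7-fold lower number from compound 3 to compound 4 (0.67 log units; beyond the scatter) and points to a lower number, though with wide uncertainty. For compound 4 the estimated value is 120 nM, with an expected range from 30 nM to 450 nM.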

Compound 4, half-maximal inhibitory concentration: > 10000 nM
Compound 4 ended at the assay's limit; the forecaster's own chance of this, stated with the estimate: 2%; at least 83-fold (1.92 log units) between middle value and limit.
By their numbers in this assay, from the lowest: compound 2; then compounds 3 and 1 (each within the scatter of the next). At a limit, above all of these: compound 4.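

In this assay compound 4 gives > 10000 nM, which is a limit of the assay and not a number: the limit of > 10000 nM in this assay, at which 1 of the 4 values shown sits.

A carbonyl on the nitrogen on an aromatic ring therefore does not carry the low number of compound 2 by itself, since the group on that carbonyl carbon decides much of the outcome, with methyl(phenyl)amino in place of 4-fluorophenyl giving an at least 220-fold higher number from compound 2 to compound 4 (2.34 log units; beyond the scatter). Methyl(phenyl)carbamoyl also reads above both sulfonyl compounds, with an at least 17-fold higher number from compound 3 to compound 4 (1.25 log units; beyond the scatter) and an at least 11-fold higher number from compound 1 to compound 4 (1.05 log units; beyond the scatter), so on this nitrogen the carbonyl-linked compounds now span a wider range than the sulfonyl pair.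

The compounds shown do not separate the parts of the change from compound 2 to compound 4, namely the nitrogen entering at the carbonyl, the methyl on it and the loss of fluoro, and they give no cause for the rise. A phenylamino or a benzyl group on the same carbonyl would help to tell these parts apart, and a 4-fluorophenyl on the carbamoyl nitrogen would test the fluoro alone.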